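This account rests on a few compounds, and the source may have more. Where it says the series, first, only, none or still open, it means among the compounds named here.

Compound 1, whose structure is `C=C1[C@H](C)CCC[C@]1(C)CC/C(C)=C/CC1=C(O)C(=O)C=C(OC)C1=O`, carries a terpene chain attached to a quinone-like core that bears a hydroxy group and a methoxy group. In a functional assay on KB16 cells (Homo sapiens) for cytotoxicity, read by MTT assay (a lower number here means a stronger inhibitor, a higher number a weaker inhibitor), compound 1 gives 1.8 ug/mL. Within the data shown here, the only other measured compound, compound 2, has the structure `C=C1[C@H](C)CCC[C@]1(C)CC[C@@]1(C)C=Cc2c(OC(C)=O)c(OC)cc(OC(C)=O)c2O1`, in which the chain is folded into a cyclized core bearing two acetate groups. In this assay compound 2 reaches only a limit, reported as > 10 ug/mL. Among the measured compounds shown here, compound 1 therefore stands as the only real number in the set; the second value is the limit of > 10 ug/mL in this assay, at which 1 of the 2 values shown sits, so no step between measured compounds can be drawn.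

Compound 3, with the structure `C=C1[C@H](C)CCC[C@]1(C)CC/C(C)=C/CC1=C(OC)C(=O)C=C(OC)C1=O`, is the next compound to be examined. It differs from compound 1 by methyl in place of hydrogen on an oxygen on an unsaturated carbon, a change that is small in heavy-atom count and leaves the core and chain otherwise untouched. For the measured compounds named here, with no measured step of this kind to lean on, the expectation is for a shift in this assay from compound 1 to compound 3 of a 1.9-fold higher number from compound 1 to compound 3 (0.29 log units; within the scatter), in the direction of a somewhat weaker inhibitor, though a result within the scatter would not be surprising. On that basis compound 3 is expected to give about 3.5 ug/mL, in a range from 1.2 ug/mL to 10 ug/mL.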

Compound 3, half-maximal inhibitory concentration: > 10 ug/mL
Compound 3: no number, only a limit (the forecaster's own chance of this, stated with the estimate: 20%); middle value at least 2.8-fold (0.45 log units) away from the limit.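

In this assay, among these compounds, the change from hydroxy to methoxy, with methyl in place of hydrogen on an oxygen on an unsaturated carbon, is the first change in one place that can be read in this set, and it gives an at least 5.5-fold higher number from compound 1 to compound 3 (0.74 log units; beyond the scatter). Compound 3 gives > 10 ug/mL, which is a limit of the assay and not a number. This single added carbon on that oxygen is therefore enough to move the read-out beyond the scatter towards a weaker inhibitor, but the full size of the loss cannot be given because the step rests on a limit: the limit of > 10 ug/mL in this assay, at which 2 of the 3 values shown sit.

The compounds shown leave open how this place responds to other groups, such as an amine or an ethoxy group in place of the hydroxy, and so whether the loss follows the missing hydrogen or the added methyl. They also leave open how far compound 3 lies from compound 1 in this assay, and whether any group at this place matches the hydroxy of compound 1.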